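The source may hold more compounds than are shown below. What is called first, only, known or untested is meant among the compounds shown, and "the series" means these compounds.

In a functional assay on HEK293 cells for antagonist activity at transient receptor potential M8 protein (Canis lupus familiaris), read by FLIPR and calcium flux (a higher number here means a weaker inhibitor, a lower number a stronger inhibitor), compound 1 `FC(F)(F)c1ccccc1-c1ccc2[nH]c(C3=NCC4(CCCCC4)O3)nc2c1` gives 61 nM, compound 2 `FC(F)(F)c1ccccc1-c1ccc2[nH]c(C3=NOC4(CCCCC4)C3)nc2c1` gives 3.1 nM, and compound 3 `Fc1ccccc1-c1ccc2[nH]c(C3=NOC4(CCCCC4)C3)nc2c1` gives 2.9 nM. Compound 3 and compound 2 give numbers that cannot be told apart, and both lie well under compound 1. Compound 4 `FC(F)(F)Oc1ccccc1-c1ccc2[nH]c(C3=NOC4(CCCCC4)C3)nc2c1` differs from compound 3 by trifluoromethoxy in place of fluoro on an aromatic carbon. For the measured compounds named here, the one measured step that bears on this change is a 1.1-fold lower number from compound 2 to compound 3 (0.03 log units; within the scatter), which exchanged one group for another at the same place and left the number where it was. Going by the values given here, for trifluoromethoxy itself no measured step exists, so the expectation rests on that single step and allows a wider range. Compound 4 is therefore expected to give 4 nM, between 1.5 nM and 12 nM. The expected step is a 1.4-fold higher number from compound 3 to compound 4 (0.14 log units; within the scatter).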

Compound 4, half-maximal inhibitory concentration: 1.1 nM
Beside the measured number, compound 4's estimate is 3.6-fold (0.56 log units) above it; measured number below the stated range.
By their numbers in this assay, from the lowest: compound 4; then compounds 3 and 2 (each within the scatter of the next); then compound 1.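

Fluoro and trifluoromethyl at this place could not be told apart, but trifluoromethoxy can, with a 2.6-fold lower number from compound 3 to compound 4 (0.42 log units; beyond the scatter) and a 2.8-fold lower number from compound 2 to compound 4 (0.45 log units; beyond the scatter) in this assay. So the number on an aromatic carbon ortho to a large group does respond to the group placed there, and the largest of the three groups gives the lowest number. Nothing shown here explains this gain.

On these data alone, whether an amine, a carboxylic acid or a longer chain at this place would lower the number further remains open. So does whether trifluoromethoxy would give a similar step on the core of compound 1.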